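This account rests on a few compounds, and the source may have more. Where it says the series, first, only, none or still open, it means among the compounds named here.

Two pairs of compounds share the same single structural change. Compound 1 `Cc1ccc(-c2cc(=O)c3ccc(C)cc3o2)cc1` and compound 2 `COc1ccc(-c2cc(=O)c3ccc(C)cc3o2)cc1` differ only by methyl in place of methoxy on an aromatic carbon; in an in vitro assay on BTI-TN-5B1-4 cells for inhibition of Amine oxidase [flavin-containing] A (Homo sapiens), tested at 100 uM (a higher number here means more inhibition at the concentration tested (going by the name of the read-out), a lower number less inhibition), compound 2 gives 40%, and compound 1 gives 40%, so that no change at the digits printed from compound 2 to compound 1 (within the scatter). Compound 3 `COc1ccc(C2CC(=O)c3ccc(OC)cc3O2)cc1` rests on a different core, and the difference between the two cores is not broken down here; in this assay compound 3 is reported as "not active" (no number reported). Compound 4 `COc1ccc2c(c1)OC(c1ccc(C)cc1)CC2=O` stands to compound 3 as compound 1 stands to compound 2, differing by methyl in place of methoxy on an aromatic carbon, the same kind of change. Since that change left compound 1 and compound 2 within the scatter of each other, compound 4 is expected to stay close to compound 3. Compound 4 is estimated at 10% in this assay, between 0% and 30%.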

Compound 4, a percentage reported as inhibition, at one concentration (the size of the read-out at that concentration, not a potency): "not active" (no number reported)
Compound 4 has no reported number here, and the estimate cannot be compared.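

Neither compound 3 nor compound 4 has a number in this assay, so no step can be read between them. The compounds shown leave open whether methyl in place of methoxy alters inhibition on this core. No measurement given here bears on this result.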